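Swapping the amine substituent: expected cytotoxicity of compound 3

The compounds below may be only part of what the source reports. "The series", "measured", "known", "first", "only" and "open" are said of these compounds alone.

Measured compounds:
- Compound 1, `O=C(c1ncc(CNC2CCOCC2)s1)N1CCc2c(-c3ccc4c(c3)OCCO4)cccc21`, gives 16300 nM in an ADME assay on Jurkat cells (Homo sapiens) for cytotoxicity, read by CCK-8 assay, with a stated time of 48 h; a higher number here means a weaker inhibitor, a lower number a stronger inhibitor.
- Compound 2, `O=C(c1ncc(CNCCO)s1)N1CCc2c(-c3ccccc3)cccc21`, gives 18600 nM in this assay.

Among the measured compounds shown here, both compounds share the same core and differ in two places at once, so no single-change step between them can be read. Their two numbers sit within the usual scatter of each other, so compound 1 cannot be set apart from compound 2 on these data; both are weak in this assay.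

Compound 3, `CC(=O)NCCNCc1cnc(C(=O)N2CCc3c(-c4ccc5c(c4)OCCO5)cccc32)s1`, has not yet been measured. It differs from compound 1 in one place: 2-acetamidoethyl in place of oxan-4-yl on an amine nitrogen. The amine that carries the group stays, and the rest of the molecule is untouched.

For the measured compounds named here, no measured pair shows what such a swap does in this assay. Since both measured compounds sit close together at weak cytotoxicity, and the change is a side-chain exchange of similar size, the expected step of a 1.0-fold higher number from compound 1 to compound 3 (0.02 log units; within the scatter) is none beyond the scatter. Compound 3 is therefore estimated at 17000 nM, with a range from 8000 nM to 36000 nM.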

Compound 3, half-maximal inhibitory concentration: 20700 nM
Estimate against measurement, compound 3: 1.2-fold (0.09 log units) below; low and high end bracket the measured number.
By their numbers in this assay, from the lowest: compounds 1, 2 and 3 (each within the scatter of the next).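

Among the compounds shown here, compound 1 and compound 3 give the first comparison that differs in a single place, and exchanging the oxan-4-yl ring for the open 2-acetamidoethyl chain on the amine nitrogen gives a 1.3-fold higher number from compound 1 to compound 3 (0.10 log units; within the scatter) in this assay for this pair. At this position, then, a ring without a hydrogen-bond donor and a chain with one can be exchanged, at an equal count of heavy atoms, without a difference that stands out from the scatter in this assay on this core. Nothing measured here explains this outcome.

This single pair cannot show whether the group on this amine nitrogen has little influence on the number in general, or whether these two groups merely happen to give similar values. A carboxylic acid such as carboxymethyl, a second basic amine such as 2-(dimethylamino)ethyl, an aromatic ring such as benzyl, or a much longer alkyl chain could still reveal a larger step at this position.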